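The source may hold more compounds than are shown below. What is called first, only, known or untested is meant among the compounds shown, and "the series" means these compounds.

Four compounds share one core and differ only in the group on a saturated ring carbon: compound 1 `CC1=C(C(=O)Nc2ccccc2Cl)C(c2ccc(Cl)cc2)NC(=O)N1`, compound 2 `CC1=C(C(=O)Nc2ccccc2Cl)C(c2cccc(Br)c2)NC(=O)N1`, compound 3 `CC1=C(C(=O)Nc2ccccc2Cl)C(c2ccc(Br)cc2)NC(=O)N1` and compound 4 `CC1=C(C(=O)Nc2ccccc2Cl)C(c2cccc([N+](=O)[O-])c2)NC(=O)N1`. Their effect on host cells was followed in an ADME assay on Vero cells (Chlorocebus sabaeus) for cytotoxicity, read by XTT assay, with a stated time of 72 h; a lower number here means that less compound is tolerated, a higher number that more compound is tolerated. Compound 1 is recorded in this assay as "non-toxic" (no number reported), without a number. For compound 2 the result in this assay is a limit of the assay, > 100000 nM. For compound 3 the result in this assay is likewise a limit, > 100000 nM. Within the data shown here, the only single-point step among the measured compounds is a step that the two limits leave unreadable from compound 2 to compound 3, which runs between two limits and so cannot be sized. Compound 3 therefore stands at the limit of > 100000 nM in this assay, at which 2 of the 3 values shown sit, with no numbered value to rank it against. The change to compound 4 is 3-nitrophenyl in place of 4-bromophenyl on a saturated ring carbon. Among the measured compounds shown here, no measured step involves a nitro group, so the expectation rests only on compound 2 and compound 3 both sitting at the limit (the limit of > 100000 nM in this assay, at which 2 of the 3 values shown sit). The step that the limit leaves unreadable from compound 3 to compound 4 is expected to stay within the scatter. Compound 4 is expected to give about 120000 nM, within 40000 nM to 300000 nM, most likely reported again only as a limit.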

Compound 4, half-maximal cytotoxic concentration: "non-toxic" (no number reported)
For compound 4 the study gives words and no number; the estimate stays without a comparison.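

In this assay, among these compounds, compound 4 is recorded as "non-toxic" (no number reported), and no step from compound 3 to compound 4 can be read. For compound 3 the result is only a limit, > 100000 nM. The compounds shown leave open at what concentration, if any, each of the four would harm these cells, and whether their groups differ in this.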